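The source may hold more compounds than are shown below. What is called first, only, known or untested is meant among the compounds shown, and "the series" means these compounds.

Measured in an ADME assay on microsomes from liver (Homo sapiens) for metabolic stability, with a stated time of 10 min (on this read-out lower numbers stand for a less stable compound and higher numbers for a more stable compound), so far
compound 1 `Fc1ccccc1-c1ccc2[nH]c(C3=NOC4(CCCCC4)C3)nc2c1` gives 79%
compound 2 `Fc1cccc(C(F)(F)F)c1-c1ccc2[nH]c(C3=NOC4(CCCCC4)C3)nc2c1` gives 38%
compound 3 `Fc1cccc(OC(F)(F)F)c1-c1ccc2[nH]c(C3=NOC4(CCCCC4)C3)nc2c1` gives 100%

Compound 1 stands second highest of these three numbers. Compound 4 `Fc1ccccc1-c1cc(C(F)(F)F)c2[nH]c(C3=NOC4(CCCCC4)C3)nc2c1` differs from it by trifluoromethyl in place of hydrogen on an aromatic carbon, a trifluoromethyl in place of hydrogen on an aromatic carbon, ortho to a fused ring and meta to a 2-fluorophenyl group. Going by the values given here, the nearest precedent is a number 41 percentage points lower from compound 1 to compound 2 (beyond the scatter), where trifluoromethyl enters on a different aromatic carbon. The trifluoromethoxy case points the other way, with a number 21 percentage points higher from compound 1 to compound 3 (beyond the scatter), and it bears less directly. A modest drop is therefore expected, estimated as a number 19 percentage points lower from compound 1 to compound 4 (beyond the scatter), with real uncertainty from the change of place. For compound 4 the expected value is 60%, with an estimated range of 30% to 90%.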

Compound 4, percent of the compound remaining: 71%
Beside the measured number, compound 4's estimate is 11 percentage points below it; the range from low to high includes it.
By their numbers in this assay, from the lowest: compound 2; then compounds 4 and 1 (each within the scatter of the next); then compound 3.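

In this assay, trifluoromethyl in place of hydrogen on this aromatic carbon, ortho to a fused ring and meta to a 2-fluorophenyl group, gives a number 8 percentage points lower from compound 1 to compound 4 (within the scatter). The same replacement on a different aromatic carbon gives a number 41 percentage points lower from compound 1 to compound 2 (beyond the scatter), so in these compounds the outcome of this change depends on its place. Nothing at hand accounts for that difference between the two places.

On these data alone, whether this carbon also accepts an amine, a carboxylic acid or trifluoromethoxy remains open. Also open, as far as these compounds go, is whether trifluoromethyl here would behave the same with other groups on the 2-fluorophenyl ring.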